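From diethylamino to amino in compound 4

The source may hold more compounds than are shown below. What is called first, only, known or untested is meant among the compounds shown, and "the series" means these compounds.

In a toxicity assay on MDCK cells (Canis lupus familiaris) for cytotoxicity, read by CCK-8 assay, with a stated time of 48 h (a lower number here means that less compound is tolerated, a higher number that more compound is tolerated), compound 3 `CCN(CC)c1ccc(C(=O)NNc2c(Br)cccc2Br)cc1` gives 34000 nM, the lower of the two actual numbers in the series. Compound 1 `COC(=O)c1ccc(C(=O)NNc2c(Br)cccc2Br)cc1` gives 87600 nM. Compound 2 `O=C(NNc1c(Br)cccc1Br)c1ccccc1` gives only a limit of the assay, > 100000 nM.

Compound 4 `Nc1ccc(C(=O)NNc2c(Br)cccc2Br)cc1` carries amino in place of diethylamino on an aromatic carbon, para to a large group: amino in place of diethylamino on an aromatic carbon. Within the data shown here, two measured steps bear on this change, both ending at diethylamino: an at least 2.9-fold lower number from compound 2 to compound 3 (0.46 log units; beyond the scatter), and a 2.6-fold lower number from compound 1 to compound 3 (0.41 log units; beyond the scatter). Going by these two steps, losing diethylamino is expected to raise the number in this assay by a similar or smaller amount. The expected move is a 2.1-fold higher number from compound 3 to compound 4 (0.31 log units; beyond the scatter). For compound 4 the estimate is 70000 nM, with an expected range of 30000 nM to 110000 nM.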

Compound 4, half-maximal cytotoxic concentration: > 100000 nM
Compound 4 gave a limit, no number; the forecaster's own chance of this, stated with the estimate: 35%; middle value at least 1.4-fold (0.15 log units) away from the limit.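

In this assay, amino in place of diethylamino gives an at least 2.9-fold higher number from compound 3 to compound 4 (0.46 log units; beyond the scatter), so the lower number of compound 3 goes with the whole diethylamino group, not with a nitrogen on this aromatic carbon as such. Amino in place of methoxycarbonyl gives an at least 1.1-fold higher number from compound 1 to compound 4 (0.05 log units; that floor lies within the scatter), a floor within the scatter, which sets no order between these two groups. The step from compound 2 to compound 4 cannot be read, because both values are limits: the limit of > 100000 nM in this assay, at which 2 of the 4 values shown sit.

Open, going by these compounds, is how much alkyl on the nitrogen the lower number needs: methylamino or ethylamino would sit between amino and diethylamino. On these data alone, whether a cyclic amine such as piperidine behaves like diethylamino also remains open.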